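The source may report more compounds than this note shows. Statements on the series, on what has been measured and on what is new or still open speak of the compounds shown alone.

Working notes on the series. Of the compounds shown here, three on the shared core have been measured in a physicochemical assay for lipophilicity, measured as octanol-water partition; a lower number here means a more polar compound, a higher number a more lipophilic compound. Compound 1 `CC1=C(C(=O)OCc2ccccn2)C(c2cccc(O)c2)C2=C(CCCC2=O)N1` gives 1.58 in this assay. Compound 2 `CC1=C(C(=O)OCc2cccnc2)C(c2ccccc2[N+](=O)[O-])C2=C(CCCC2=O)N1` gives 1.51, and compound 3 `COc1ccc(C2C(C(=O)OCc3cccnc3)=C(C)NC3=C2C(=O)CCC3)cc1` gives 1.54. Compound 1 carries the highest of the three numbers, but its gaps to compound 3 and to compound 2 lie within the usual scatter, so the three values are indistinguishable on this evidence. Among the measured compounds shown here, the one measured step, 4-methoxyphenyl in place of 2-nitrophenyl on a saturated ring carbon, runs a number 0.03 log units higher from compound 2 to compound 3 (within the scatter) and is within the scatter.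

Compound 4 `CC1=C(C(=O)OCc2ccccn2)C(c2cccs2)C2=C(CCCC2=O)N1` is not yet measured in this assay. Against compound 1 the change is thiophen-2-yl in place of 3-hydroxyphenyl on a saturated ring carbon. For the measured compounds named here, no measured step exchanges the group on the saturated ring carbon for a five-membered aromatic ring, and none removes a hydrogen-bond donor, so the step from compound 2 to compound 3 bears on it only loosely: it shows that swapping one six-membered aromatic ring for another left this assay unchanged. The expectation here is a modest rise from compound 1 to compound 4, of about a number 0.52 log units higher from compound 1 to compound 4 (beyond the scatter). For compound 4 the estimated value in this assay is 2.1, with a range from 1.7 to 2.5.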

Compound 4, partition coefficient: 1.77
For compound 4 the middle estimate is 0.33 log units above the measured one; measured number inside the range.
By their numbers in this assay, from the lowest: compounds 2, 3, 1 and 4 (each within the scatter of the next).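

In this assay the exchange of 3-hydroxyphenyl for thiophen-2-yl on a saturated ring carbon gives a number 0.19 log units higher from compound 1 to compound 4 (within the scatter), so this position has now taken a five-membered aromatic ring with 1 hetero atom and a group with 0 hydrogen-bond donors without a reading beyond the scatter. Among the compounds shown here, the earlier step, a number 0.03 log units higher from compound 2 to compound 3 (within the scatter), exchanged only one six-membered aromatic ring for another, whereas this step changes the ring size, brings a hetero atom into the ring and removes the hydrogen-bond donor, all at once, so the effect of each of these differences cannot be separated here. No independent measurement in the series accounts for the size of this step.

Open, going by these compounds, is whether an amine or a carboxylic acid on the aromatic ring at this carbon, or a longer chain in place of that ring, would move the number in this assay beyond the scatter. Also open, on these data alone, is whether thiophen-2-yl would read the same way alongside the different ester attachment carried by compound 2 and compound 3.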